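Ring size of the charged terminus in the chain series

The compounds below may be only part of what the source reports. "The series", "measured", "known", "first", "only" and "open" are said of these compounds alone.

Measured so far in an assay on LX2 cells for inhibition of COL1A1 promoter (Homo sapiens), read by a luciferase reporter, with a stated time of 24 h, tested at 50 uM; a lower number here means a weaker effect, a higher number a stronger effect of the compound at the concentration tested:
Compound 1 `Cc1ccc(-n2cc(C(=O)Nc3cc(F)cc(F)c3)c(=O)c3ccc(N(C)C)nc32)cc1OCCCCCCC[N+]1(C)CCCCC1` gives 45.1%.
Compound 2 `CN(C)c1ccc2c(=O)c(C(=O)Nc3cc(F)cc(F)c3)cn(-c3ccc(Cl)c(OCCCCCCC[N+]4(C)CCCCC4)c3)c2n1` gives 90.5%.

Among the measured compounds shown here, compound 1 stands lowest of the two numbers; the one measured step, a number 45.4 percentage points higher from compound 1 to compound 2 (beyond the scatter), is large and beyond the scatter. Compound 3 `CC[N+]1(CCCCCCCOc2cc(-n3cc(C(=O)Nc4cc(F)cc(F)c4)c(=O)c4ccc(N(C)C)nc43)ccc2C)CCCC1` differs from compound 1 by a group of 7 heavy atoms (6 carbon, 1 nitrogen; one five-membered non-aromatic ring with 1 hetero atom) in place of a group of 7 heavy atoms (6 carbon, 1 nitrogen; one six-membered non-aromatic ring with 1 hetero atom), on a saturated chain carbon, seven bonds along the chain from an oxygen on an aromatic ring. For the measured compounds named here, no measured step touches this part of the molecule, so nothing here points to a change beyond the scatter, and the step of a number 0.1 percentage points lower from compound 1 to compound 3 (within the scatter) is expected to stay within it. Compound 3 is therefore estimated at 45%, with a range from 25% to 65%.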

Compound 3, a percentage reported as inhibition, at one concentration (the size of the read-out at that concentration, not a potency): 81.4%
Beside the measured number, compound 3's estimate is 36.4 percentage points below it; the whole stated range lies below it.
By their numbers in this assay, from the lowest: compound 1; then compounds 3 and 2 (each within the scatter of the next).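

The charged terminus is not a silent position: in this assay, the five-membered ring group in place of the six-membered ring group gives a number 36.3 percentage points higher from compound 1 to compound 3 (beyond the scatter) with 7 heavy atoms and net charge +1 in both groups. The end of the chain therefore responds to a rearrangement of the same atoms, so the aromatic carbon bearing methyl or chloro is not the only place that moves this read-out. No measurement at hand explains the step.

Open, going by these compounds, is whether chloro in place of methyl adds to the gain from the five-membered ring group. Also open, on these data alone, is how a seven-membered ring or a morpholine ring at this terminus would read.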